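Aryl groups on the ring nitrogen of the amide series

The compounds below may be only part of what the source reports. "The series", "measured", "known", "first", "only" and "open" are said of these compounds alone.

Three members of the series have been measured in a functional assay on HOS-TE85 cells (Homo sapiens) for inhibition, read by CCK-8 assay, with a stated time of 72 h, tested at 1 uM; a lower number here means less inhibition, a higher number more inhibition at the concentration tested (going by the name of the read-out). Compound 1 `CCN1C(=O)CSC1c1cccc(C(=O)NCCCCc2ccccc2)c1` gives 0%. Compound 2 `O=C(NCCCCc1ccccc1)c1cccc(C2SCC(=O)N2c2cccc(F)c2)c1` gives 94%, and compound 3 `COc1cccc(OC)c1N1C(=O)CSC1c1cccc(C(=O)NCCCCc2ccccc2)c1` gives 95%. Compound 3 carries the highest number of the three, but its gap to compound 2 is within the scatter; only compound 1 lies far below it. Compound 4 `COc1ccc(N2C(=O)CSC2c2cccc(C(=O)NCCCCc3ccccc3)c2)c(OC)c1` is the next member: 2,4-dimethoxyphenyl in place of 2,6-dimethoxyphenyl on an amide-type nitrogen in a ring. Among the measured compounds shown here, three measured steps bear on this. Replacing ethyl by an aryl group gave a number 94 percentage points higher from compound 1 to compound 2 (beyond the scatter) and a number 95 percentage points higher from compound 1 to compound 3 (beyond the scatter). Exchanging one aryl for another gave a number 1 percentage points higher from compound 2 to compound 3 (within the scatter), no step beyond the scatter. The step expected for compound 4 in this assay is therefore a number 3 percentage points lower from compound 3 to compound 4 (within the scatter). Compound 4 is estimated at 92%, within a range of 78% to 99%.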

Compound 4, a percentage reported as inhibition, at one concentration (the size of the read-out at that concentration, not a potency): 58%
Estimate against measurement, compound 4: 34 percentage points above, outside the stated range (below it).
By their numbers in this assay, from the lowest: compound 1; then compound 4; then compounds 2 and 3 (each within the scatter of the next).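

In this assay, aryl groups on this nitrogen are not interchangeable: with the same atoms, 2,4-dimethoxyphenyl in place of 2,6-dimethoxyphenyl gives a large drop (a number 37 percentage points lower from compound 3 to compound 4 (beyond the scatter)). The same group also falls short of 3-fluorophenyl (a number 36 percentage points lower from compound 2 to compound 4 (beyond the scatter)), so the earlier aryl exchange understated how much the substitution pattern can matter, although 2,4-dimethoxyphenyl still far exceeds ethyl (a number 58 percentage points higher from compound 1 to compound 4 (beyond the scatter)). No available evidence accounts for this difference. Still open, as far as these compounds go, is how a hydroxyl or an amine in place of methoxy on this aryl group would read.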